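Propyl for hydrogen on the ring oxygen: compound 4

A few compounds are considered here, and "the series" means these few. Any claim that something is new, unique, unknown or untested is made for them only; others in the source may bear on it.

compound 1 `Cc1cccc2c(=O)cc(/C=C/[S+](C)[O-])oc12`: 6800 nM
compound 2 `C[S+]([O-])/C=C/c1cc(=O)c2cc(O)ccc2o1`: > 10000 nM
compound 3 `COc1ccc2c(=O)cc(/C=C/[S+](C)[O-])oc2c1`: 7800 nM

In a functional assay on DLD-1 cells (Homo sapiens) for cytotoxicity, with a stated time of 48 h (on this read-out lower numbers stand for stronger inhibition and higher numbers for weaker inhibition), compound 1 gives 6800 nM and compound 3 gives 7800 nM. For compound 2 the assay reports only a limit, > 10000 nM, so it sits at the limit of > 10000 nM in this assay, at which 1 of the 3 values shown sits, and has no numbered place among the three values. Compound 4 `CCCOc1ccc2oc(/C=C/[S+](C)[O-])cc(=O)c2c1` is next to be measured in this assay. It differs from compound 2 in one place: propyl in place of hydrogen on an oxygen on an aromatic ring. Among the compounds with values here, no pair of measured compounds differs in a single place, so no step of this kind has been measured. Since compound 3 gives 7800 nM in this assay, compound 4 is expected at 8000 nM (range 3000 nM to 20000 nM). The expected step is an at least 1.2-fold lower number from compound 2 to compound 4 (0.09 log units; that floor lies within the scatter), which against a limit cannot be sized beyond saying a number is expected.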

Compound 4, half-maximal inhibitory concentration: 6200 nM
The estimate for compound 4 lay 1.3-fold (0.11 log units) above the measured number; the measured number falls inside the stated range.
By their numbers in this assay, from the lowest: compounds 4, 1 and 3 (each within the scatter of the next). At a limit, above all of these: compound 2.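

In this assay, within the data shown here, hydroxy to propoxy gives the only step read so far at this oxygen on an aromatic ring: an at least 1.6-fold lower number from compound 2 to compound 4 (0.20 log units; that floor lies within the scatter). With propyl in place of hydrogen, the series gains a measured number at this position, but the other end of the step is only a limit: the limit of > 10000 nM in this assay, at which 1 of the 4 values shown sits.

The step therefore has a floor and no true size. On these data alone, whether a longer chain such as hexyl, or a chain ending in an amine, on this oxygen would shift the number beyond the scatter remains open.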